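The compounds below may be only part of what the source reports. "The series", "measured", "known", "first", "only" and "open" are said of these compounds alone.

Measured compounds:
Compound 1, `COc1cc(OC)c2c(C)c(C(=O)NCc3ccccc3)oc2c1C(N)=O`, gives 54800 nM in a functional assay on A549 cells (Homo sapiens) for cytotoxicity, read by MTT assay; on this read-out higher numbers stand for weaker inhibition and lower numbers for stronger inhibition.
Compound 2, `COc1cc(OC)c2c(C)c(C(N)=O)oc2c1C(N)=O`, gives 39400 nM in this assay.
Compound 3, `COc1cc(OC)c2c(C)c(C=O)oc2c1Br`, gives 49500 nM in this assay.

Among these three numbers, compound 3 stands second highest. Its nearest neighbour is compound 1, whose number lies within the scatter of it, and the furthest is compound 2, which also lies within the scatter. Among the measured compounds shown here, the only single-point step among the measured compounds, a 1.4-fold lower number from compound 1 to compound 2 (0.14 log units; within the scatter), is within the scatter as well.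

Compound 4, `COc1cc(OC)c2c(C)c(C=O)oc2c1C(N)=O`, has not been measured. It differs from compound 3 by carbamoyl in place of bromo on an aromatic carbon. For the measured compounds named here, no measured step concerns an exchange of bromo for carbamoyl. Going by the values given here, compounds 1 and 2 carry carbamoyl rather than bromo, but each also differs from compound 3 elsewhere, so their values show only that compounds bearing carbamoyl can sit within the scatter of compound 3. Among the compounds with values here, the one step on record, from benzyl to hydrogen, stayed within the scatter. On this basis no step beyond the scatter is expected in this assay in either direction. Compound 4 is therefore estimated at 45000 nM, with a range from 20000 nM to 100000 nM. The step that this estimate means, a 1.1-fold lower number from compound 3 to compound 4 (0.04 log units; within the scatter), is expected to stay within the scatter.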

Compound 4, half-maximal inhibitory concentration: 63800 nM
For compound 4 the middle estimate is 1.4-fold (0.15 log units) below the measured one, within the range that was stated.
By their numbers in this assay, from the lowest: compounds 2, 3, 1 and 4 (each within the scatter of the next).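

In this assay the exchange of bromo for carbamoyl on this aromatic carbon, which lies para to one methoxy group and ortho to another, now has a step of its own in a 1.3-fold higher number from compound 3 to compound 4 (0.11 log units; within the scatter) and so the position carries either group without a shift beyond the scatter. With carbamoyl held at this position, the carbonyl carbon adds two further steps, since hydrogen in place of amino gives a 1.6-fold higher number from compound 2 to compound 4 (0.21 log units; within the scatter) and hydrogen in place of benzylamino gives a 1.2-fold higher number from compound 1 to compound 4 (0.07 log units; within the scatter) and neither exchange separates the compounds. Across these four compounds, then, no change at either place has yet produced a step beyond the scatter, whether it enters at the aromatic carbon or on the carbonyl carbon.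

No measurement that could account for these results is available. The compounds shown leave open whether an amine, a carboxylic acid or a nitrile on this aromatic carbon, or a longer chain on the amide nitrogen of the carbonyl group, would give a step beyond the scatter in this assay and thus show that either place matters in this assay.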